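Reversing the Amine Linker: Expected Efficacy of Compound 3

This account rests on a few compounds, and the source may have more. Where it says the series, first, only, none or still open, it means among the compounds named here.

Of the compounds shown here, two have been measured so far. Compound 1 `CN(Cc1cccc(C(=O)O)c1)c1ccc(OCc2c(-c3c(Cl)cccc3Cl)noc2C2CC2)nc1C(F)(F)F` carries a 3-carboxyphenyl group; in an assay on isolated protein for agonist activity at Bile acid receptor (Homo sapiens), read by FRET (on this read-out lower numbers stand for smaller maximal responses and higher numbers for larger maximal responses), compound 1 reaches 102%. Compound 2 `CN(Cc1ccc(C(=O)O)cc1)c1ccc(OCc2c(-c3c(Cl)cccc3Cl)noc2C2CC2)nc1C(F)(F)F` carries the 4-carboxyphenyl group instead, and in this assay compound 2 reaches 109%. Within the data shown here, the only measured step, a number 7 percentage points higher from compound 1 to compound 2 (within the scatter), shows that moving the acid around the ring leaves the maximal response essentially unchanged. Compound 2 has the higher of the two numbers, but its gap to compound 1 lies within the scatter, so the two are best regarded as equivalent.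

Compound 3 `CC(Nc1ccc(C(=O)O)cc1)c1ccc(OCc2c(-c3c(Cl)cccc3Cl)noc2C2CC2)nc1C(F)(F)F` is built from the same atoms as compound 2, joined differently: 1-((4-carboxyphenyl)amino)ethyl in place of (4-carboxybenzyl)(methyl)amino on an aromatic carbon. Among the measured compounds shown here, no measured step reflects a rearrangement of this kind, so the single step available gives no direct guidance; it only shows that this part of the molecule tolerated one change without loss of response. The expectation for compound 3 is therefore a step of a number 9 percentage points lower from compound 2 to compound 3 (within the scatter) in this assay, with wide uncertainty. Compound 3 is estimated at 100%, between 70% and 120%.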

Compound 3, largest response reached (reported as efficacy), in percent of the reference or control that the assay uses: 99%
Compound 3: middle estimate off by 1 percentage points, on the high side, within the range that was stated.
By their numbers in this assay, from the lowest: compounds 3, 1 and 2 (each within the scatter of the next).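

The earlier step only moved the acid around the ring, whereas this change rebuilds the link itself: in 1-((4-carboxyphenyl)amino)ethyl the nitrogen sits on the carboxyphenyl ring and carries a hydrogen, the methyl has moved onto the chain carbon, and that carbon, rather than the nitrogen, is bound to the shared core. In this assay this rearrangement gives a number 10 percentage points lower from compound 2 to compound 3 (within the scatter) and, set against the other acid position, a number 3 percentage points lower from compound 1 to compound 3 (within the scatter) so all three compounds count as equivalent, and the maximal response holds up when the link is joined in a different way as well as when the acid moves. Nothing available here explains why the response holds up under this rearrangement.

The compounds shown leave open whether the response also survives in 1-((3-carboxyphenyl)amino)ethyl, which would combine the new link with the other acid position, or with a longer chain joining the carboxyphenyl ring to the core. On these data alone, all three also carry a carboxylic acid, so it remains open what happens when a primary amide or a tetrazole takes its place.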